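The source may hold more compounds than are shown below. What is called first, only, known or untested is meant among the compounds shown, and "the series" means these compounds.

Measured so far in a functional assay on HUVEC cells (Homo sapiens) for inhibition, tested at 5 ug/mL; on this read-out lower numbers stand for a weaker effect and higher numbers for a stronger effect at the one concentration tested:
compound 1 `COc1cc(/C=C/C(=O)c2cccc(N)c2)ccc1O` — 50%
compound 2 `COc1cc(/C=C/C(=O)c2cccc(NC(=O)c3ccc(Cl)c(Cl)c3)c2)ccc1O` — 5%

Compound 2 stands lowest of the two numbers shown; its only neighbour on this read-out is compound 1, reached through the single measured step, a number 45 percentage points lower from compound 1 to compound 2 (beyond the scatter). Compound 3 `COc1cc(/C=C/C(=O)c2cccc(NC(C)=O)c2)ccc1O` has not yet been measured in this assay. It differs from compound 2 in one place: methyl in place of 3,4-dichlorophenyl on a carbonyl carbon. Among the measured compounds shown here, the only measured step that bears on this change is a number 45 percentage points lower from compound 1 to compound 2 (beyond the scatter), which records how the read-out moved when hydrogen on the amide-type nitrogen of compound 1 was replaced by (3,4-dichlorophenyl)carbonyl. Compound 3 keeps an acetyl on that nitrogen but carries methyl in place of 3,4-dichlorophenyl on the carbonyl carbon, so its number is expected to fall between compound 2 and compound 1 rather than at either end. For the measured compounds named here, a single step is a thin basis, and no measured pair separates the effect of the amide itself from that of the 3,4-dichlorophenyl. The expected step is a number 20 percentage points higher from compound 2 to compound 3 (beyond the scatter), upward. Compound 3 is estimated at 25%, with a range of 5% to 50%.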

Compound 3, a percentage reported as inhibition, at one concentration (the size of the read-out at that concentration, not a potency): 15%
Estimate against measurement, compound 3: 10 percentage points above; the range from low to high includes it.
By their numbers in this assay, from the lowest: compounds 2 and 3 (each within the scatter of the next); then compound 1.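

At the nitrogen on an aromatic ring, the loss of effect in this assay does not depend on the 3,4-dichlorophenyl: acetyl in place of hydrogen is already enough for a number 35 percentage points lower from compound 1 to compound 3 (beyond the scatter) and is itself a large step beyond the scatter. On the carbonyl carbon, methyl in place of 3,4-dichlorophenyl removes the whole aromatic ring and gives only a number 10 percentage points higher from compound 2 to compound 3 (within the scatter) so this assay does not tell these two amides apart, and the identity of the group on that carbonyl carbon makes no measurable difference across this pair. No available measurement accounts for the gap between the free amine of compound 1 and the two amides.

Still open, as far as these compounds go, is whether the loss follows the carbonyl itself or any group placed on that nitrogen, a question that a simple methyl or a methanesulfonyl group on the nitrogen would address. Also open, from the compounds shown here alone, is whether a group on the carbonyl carbon that carries an amine or a carboxylic acid, as in aminoacetyl or a succinyl chain, would move the number away from that of the two amides and back toward compound 1.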